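Amide Terminus Swap: From Compound 2 to Compound 3

The compounds below may be only part of what the source reports. "The series", "measured", "known", "first", "only" and "open" are said of these compounds alone.

Compound 2 `CS(=O)(=O)NCCNC(=O)CN1CN(c2ccccc2)C2(CCN(C(=O)c3ccc(C4CCCCC4)cc3)CC2)C1=O` gives 2100 nM in an assay on HEK293 cells for displacement of a labelled ligand from NPC1-like intracellular cholesterol transporter 1 (Homo sapiens) (on this read-out higher numbers stand for weaker inhibition and lower numbers for stronger inhibition), the highest of the two numbers shown. Compound 1 `O=C(CN1CN(c2ccccc2)C2(CCN(C(=O)c3ccc(C4CCCCC4)cc3)CC2)C1=O)N1CCC(CO)CC1` gives 1100 nM in this assay. Among the measured compounds shown here, the only measured step at this position is a 1.9-fold higher number from compound 1 to compound 2 (0.28 log units; within the scatter), which stayed within the scatter. Compound 3 `NC(=O)C1CCCN(C(=O)CN2CN(c3ccccc3)C3(CCN(C(=O)c4ccc(C5CCCCC5)cc4)CC3)C2=O)C1` carries 3-carbamoylpiperidin-1-yl in place of (2-(methanesulfonamido)ethyl)amino on a carbonyl carbon. Because a 1.9-fold higher number from compound 1 to compound 2 (0.28 log units; within the scatter) was within the scatter, this second exchange at the same carbonyl carbon is expected to shift the number in this assay by no more than the scatter, a 1.5-fold lower number from compound 2 to compound 3 (0.18 log units; within the scatter). Compound 3 is therefore estimated at 1400 nM, with a range from 500 nM to 4000 nM.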

Compound 3, half-maximal inhibitory concentration: 3100 nM
The estimate for compound 3 lay 2.2-fold (0.35 log units) below the measured number; low and high end bracket the measured number.
By their numbers in this assay, from the lowest: compounds 1, 2 and 3 (each within the scatter of the next, the first and the last beyond it).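

Among the compounds shown here, at this carbonyl carbon, the first step beyond the scatter appears in this assay: a 2.8-fold higher number from compound 1 to compound 3 (0.45 log units; beyond the scatter), a modest step with 3-carbamoylpiperidin-1-yl in place of 4-(hydroxymethyl)piperidin-1-yl. The exchange of (2-(methanesulfonamido)ethyl)amino for 3-carbamoylpiperidin-1-yl, a 1.5-fold higher number from compound 2 to compound 3 (0.17 log units; within the scatter), stays within the scatter, so the two steps together show that this position responds only modestly across these three groups. No supporting evidence bears on this result. Still open, as far as these compounds go, is whether a piperidine carrying a carboxylic acid, a primary amine or a longer hydroxyalkyl chain at this carbonyl carbon would give a number clearly lower than that of compound 1.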